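From iodo to methoxy on a saturated ring carbon

The source may hold more compounds than are shown below. What is called first, only, known or untested is meant among the compounds shown, and "the series" means these compounds.

Compound 1 `C=C1C(=O)[C@]23C[C@@]1(Cl)CC[C@H]2[C@@]12C=CC(=O)[C@](C)(C(=O)O1)[C@H]2[C@@H]3C(=O)OC`: 60300 nM
Compound 2 `C=C1C(=O)[C@]23C[C@@]1(I)CC[C@H]2[C@@]12C=CC(=O)[C@](C)(C(=O)O1)[C@H]2[C@@H]3C(=O)OC`: 53200 nM

Going by the values given here, in a functional assay on A549 cells (Homo sapiens) for cytotoxicity, read by MTT assay (on this read-out higher numbers stand for weaker inhibition and lower numbers for stronger inhibition), compound 2 gives 53200 nM, and the only other measured compound, compound 1, gives 60300 nM. The two stand level, since neither value can be separated from the other within the usual scatter.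

The next compound, compound 3 `C=C1C(=O)[C@]23C[C@@]1(OC)CC[C@H]2[C@@]12C=CC(=O)[C@](C)(C(=O)O1)[C@H]2[C@@H]3C(=O)OC`, keeps the shared core and has methoxy in place of iodo on a saturated ring carbon.

Among the compounds with values here, only one measured step bears on this change, and it sits at the same ring carbon: a 1.1-fold lower number from compound 1 to compound 2 (0.05 log units; within the scatter). There, iodo in place of chloro left the number unmoved. That step involves neither an oxygen-linked group nor methoxy itself, so it is only a loose guide, and the range must stay wide. No step beyond the scatter is expected in this assay, and no direction is favoured. The estimated step is a 1.1-fold lower number from compound 2 to compound 3 (0.03 log units; within the scatter). For compound 3 the expected value is 50000 nM, with an estimated range of 20000 nM to 110000 nM.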

Compound 3, half-maximal inhibitory concentration: 54500 nM
For compound 3 the middle estimate is 1.1-fold (0.04 log units) below the measured one, and the stated range covers the measured number.
By their numbers in this assay, from the lowest: compounds 2, 3 and 1 (each within the scatter of the next).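

In this assay, methoxy in place of iodo on this saturated ring carbon gives a 1.0-fold higher number from compound 2 to compound 3 (0.01 log units; within the scatter), and methoxy in place of chloro gives a 1.1-fold lower number from compound 1 to compound 3 (0.04 log units; within the scatter). Until now only two halogens, chloro and iodo, had been compared at this carbon; methoxy is a different kind of group, attached through oxygen and bringing a hydrogen-bond acceptor that iodo lacks, yet it stands level with both, so all three groups are indistinguishable on this read-out. Nothing measured here gives a reason for this level result.

The compounds shown leave open whether any group on this carbon can move the number beyond the usual scatter in either direction. An amine, a carboxylic acid or a longer chain in this place would put that question to the test, and the same question remains for the rest of the shared core, since every comparison available so far concerns this one ring carbon.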